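This account rests on a few compounds, and the source may have more. Where it says the series, first, only, none or still open, it means among the compounds named here.

Working notes on the series in a functional assay on HeLa cells (Homo sapiens) for antiproliferative activity, read by MTT assay, with a stated time of 72 h; a lower number here means a stronger inhibitor, a higher number a weaker inhibitor: compound 2 `C/C=C1/[C@H](O[C@@H]2O[C@H](CO)[C@@H](O)[C@H](O)[C@H]2O)OC=C(C(=O)OC)[C@H]1CC(=O)OCCc1ccc(O)c(O)c1` gives 265000 nM, the highest number of the three measured so far. Compound 1 `C/C=C1/[C@H](O[C@@H]2O[C@H](CO)[C@@H](O)[C@H](O)[C@H]2O)OC=C(C(=O)OC)[C@H]1CC(=O)OCCC1CCCCC1` gives 5600 nM and compound 3 `C/C=C1/[C@H](O[C@@H]2O[C@H](COC(C)=O)[C@@H](OC(C)=O)[C@H](OC(C)=O)[C@H]2OC(C)=O)OC=C(C(=O)OC)[C@H]1CC(=O)OCCC` gives 17500 nM, both lower numbers than that of compound 2.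

The next comparison is compound 4 `C/C=C1/[C@H](O[C@@H]2O[C@H](CO)[C@@H](O)[C@H](O)[C@H]2O)OC=C(C(=O)OC)[C@H]1CC(=O)OCCc1ccccc1`, which differs from compound 2 by phenyl in place of 3,4-dihydroxyphenyl on a saturated chain carbon, two bonds along the chain from an oxygen next to a carbonyl group. In words, this is phenyl in place of 3,4-dihydroxyphenyl on a saturated chain carbon, two bonds along the chain from an oxygen next to a carbonyl group.

Among the compounds with values here, one measured step bears on it: a 47-fold higher number from compound 1 to compound 2 (1.68 log units; beyond the scatter), where 3,4-dihydroxyphenyl enters in place of cyclohexyl at the same place. Compound 4 also lacks 3,4-dihydroxyphenyl, so a large step towards a lower number is expected in this assay. Phenyl itself has not yet been measured in this series, so the size remains uncertain.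

The expected step is an 18-fold lower number from compound 2 to compound 4 (1.25 log units; beyond the scatter). For compound 4 the estimated value is 15000 nM, with an expected range of 4000 nM to 80000 nM.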

Compound 4, half-maximal inhibitory concentration: 18500 nM
The estimate for compound 4 lay 1.2-fold (0.09 log units) below the measured number; the range from low to high includes it.
By their numbers in this assay, from the lowest: compound 1; then compounds 3 and 4 (each within the scatter of the next); then compound 2.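

The step of a 14-fold lower number from compound 2 to compound 4 (1.16 log units; beyond the scatter) in this assay separates two changes that were combined in the earlier comparison of cyclohexyl with 3,4-dihydroxyphenyl: with the aromatic ring kept, removing the hydroxyl groups alone gives a large change towards a lower number. The step of a 3.3-fold higher number from compound 1 to compound 4 (0.52 log units; beyond the scatter) adds that the ring itself also matters at this place on the chain, though this change is only modest and phenyl gives the higher number of the pair. No available measurement explains either step.

From the compounds shown here alone, it remains open whether a single hydroxyl on the phenyl ring, methoxy groups in place of the hydroxyl groups, or an amine or carboxylic acid on that ring would behave like phenyl or like 3,4-dihydroxyphenyl. Going by these compounds, the effect of a longer chain between the ester oxygen and the ring is also open.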